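Swapping Methyl for Acetyl on a Fatty Acid Receptor Agonist

The source may hold more compounds than are shown below. What is called first, only, known or untested is meant among the compounds shown, and "the series" means these compounds.

Of the compounds shown here, two have been tested in a functional assay on HEK293 cells for agonist activity at Free fatty acid receptor 1 (Homo sapiens), read by fluorescence and calcium flux, with a stated time of 10 min; on this read-out lower numbers stand for an effect already at smaller amounts and higher numbers for an effect only at larger amounts of compound. Compound 1 `O=C(O)CCc1ccc(NCC2COc3ccc(Cl)cc3O2)cc1F` gives 13600 nM in this assay. Compound 2 `CC#C[C@@H](CC(=O)O)c1ccc(OC[C@H]2COc3ccc(C)cc3O2)cc1` gives 120 nM, the lower of the two numbers, and the gap between compound 1 and compound 2 lies well beyond the scatter of repeated measurements. Compound 3 `CC#C[C@@H](CC(=O)O)c1ccc(OC[C@H]2COc3ccc(C(C)=O)cc3O2)cc1` has not yet been measured. It differs from compound 2 in one place: acetyl in place of methyl on an aromatic carbon, on an aromatic carbon of the fused two-ring part of the shared core. Among the measured compounds shown here, no pair of measured compounds shows such a change, so nothing here tells its size directly. The change is small in atom count and leaves the acid and the rest of compound 2 untouched, so a step of modest size, in an uncertain direction with a slight lean toward a higher number, is expected in this assay. The expected step is a 1.7-fold higher number from compound 2 to compound 3 (0.22 log units; within the scatter). For compound 3 the estimate is 200 nM, within a range from 50 nM to 800 nM.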

Compound 3, half-maximal effective concentration: > 30000 nM
Compound 3: a limit, no number; the forecaster's own chance of this, stated with the estimate: 5%; middle value at least 150-fold (2.17 log units) from the limit.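

In this assay, putting acetyl in place of methyl on this aromatic carbon gives an at least 250-fold higher number from compound 2 to compound 3 (2.39 log units; beyond the scatter). Compounds 1 and 2 differ in more than one place and could not isolate this position, whereas this pair shows that a single small change here, with the acid and the rest of compound 2 untouched, is enough to produce a large step. The result for compound 3 is a limit of the assay and not a number, so the step has a lower bound only: the limit of > 30000 nM in this assay, at which 1 of the 3 values shown sits.

The compounds shown leave open whether the carbonyl of the acetyl matters here or whether any group longer than methyl would do the same. An ethyl group, which has no carbonyl, or a small group such as fluoro at this carbon would help to separate these two readings.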